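The source may report more compounds than this note shows. Statements on the series, on what has been measured and on what is new or still open speak of the compounds shown alone.

Within the data shown here, compound 2 `COc1cc(/C=C/C(=O)c2cccc(N)c2)ccc1O` gives 2.87 ug/mL in a functional assay on HUVEC cells (Homo sapiens) for inhibition; a higher number here means a weaker inhibitor, a lower number a stronger inhibitor; of the two numbers known it stands alongside compound 1 `COc1cc(/C=C/C(=O)c2cccc(NC(=O)c3ccc(Cl)c(Cl)c3)c2)ccc1O`, which gives 2.97 ug/mL, the two lying within the scatter of each other, as the step of a 1.0-fold lower number from compound 1 to compound 2 (0.01 log units; within the scatter) shows. Compound 3 `COC(=O)C(=O)Nc1cccc(C(=O)/C=C/c2ccc(O)c(OC)c2)c1` differs from compound 2 by (methoxycarbonyl)carbonyl in place of hydrogen on a nitrogen on an aromatic ring. Among the measured compounds shown here, the one step that bears on this site, a 1.0-fold lower number from compound 1 to compound 2 (0.01 log units; within the scatter), stayed within the scatter, so no step beyond the scatter is expected here either, and the expected step is a 1.0-fold higher number from compound 2 to compound 3 (0.00 log units; within the scatter). Compound 3 is therefore estimated at 2.9 ug/mL, within a range of 1.4 ug/mL to 6 ug/mL.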

Compound 3, half-maximal inhibitory concentration: 1.5 ug/mL
For compound 3 the middle estimate is 1.9-fold (0.29 log units) above the measured one; the measured number falls inside the stated range.
By their numbers in this assay, from the lowest: compounds 3, 2 and 1 (each within the scatter of the next).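

With (methoxycarbonyl)carbonyl on the nitrogen, the step stays within the scatter (a 1.9-fold lower number from compound 2 to compound 3 (0.28 log units; within the scatter)) in this assay, so a group with no ring behaves here as the (3,4-dichlorophenyl)carbonyl group did. Exchanging the end of that group also stays within the scatter (a 2.0-fold lower number from compound 1 to compound 3 (0.30 log units; within the scatter)), so neither group on this nitrogen separates from the others. Nothing available explains these numbers. Still open, from the compounds shown here alone, is whether any group on this nitrogen can move the number beyond the scatter. A free carboxylic acid, a basic amine or a longer alkyl chain would test this.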